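Methoxy additions on the chalcone-type series: next, compound 4

The source may hold more compounds than are shown below. What is called first, only, known or untested is meant among the compounds shown, and "the series" means these compounds.

- compound 1 `C=C(Br)C(=O)Nc1ccc(C(=O)/C=C/c2ccccc2)cc1` gives 500 nM
- compound 2 `C=C(Br)C(=O)Nc1ccc(C(=O)/C=C/c2cccc(OC)c2)cc1` gives 1100 nM
- compound 3 `C=C(Br)C(=O)Nc1ccc(C(=O)/C=C/c2ccc(OC)c(OC)c2)cc1` gives 1800 nM

All three values come from a functional assay on MOLT-4 cells (Homo sapiens) for antiproliferative activity, with a stated time of 48 h (a lower number here means a stronger inhibitor, a higher number a weaker inhibitor), and the compounds share one core. Compound 2 stands second highest of the three numbers, with compound 3 nearest to it and compound 1 furthest from it. Compound 4 `C=C(Br)C(=O)Nc1ccc(C(=O)/C=C/c2cc(OC)cc(OC)c2)cc1` is not yet measured. It differs from compound 2 by methoxy in place of hydrogen on an aromatic carbon and carries methoxy in place of hydrogen on an aromatic carbon, meta to a large group and meta to a methoxy group.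

Within the data shown here, two measured steps bear on this change, as both are the same exchange of methoxy in place of hydrogen on an aromatic carbon. The first is a 2.2-fold higher number from compound 1 to compound 2 (0.34 log units; beyond the scatter) and counts as modest. The second is a 1.6-fold higher number from compound 2 to compound 3 (0.21 log units; within the scatter) and does not clear the scatter. Among the measured compounds shown here, both run towards a higher number, but no measured compound carries its two methoxy groups as compound 4 does. A small step towards a higher number is therefore expected in this assay and it may well not clear the scatter. The estimated change is a 1.5-fold higher number from compound 2 to compound 4 (0.16 log units; within the scatter) on this reading. For compound 4 an estimated 1600 nM is expected, with an estimated range of 700 nM to 3500 nM for the coming measurement.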

Compound 4, half-maximal inhibitory concentration: 1500 nM
Beside the measured number, compound 4's estimate is 1.1-fold (0.03 log units) above it, and the stated range covers the measured number.
By their numbers in this assay, from the lowest: compound 1; then compounds 2, 4 and 3 (each within the scatter of the next).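

Adding a methoxy meta to a large group and meta to a methoxy group gives a 1.4-fold higher number from compound 2 to compound 4 (0.13 log units; within the scatter) in this assay, so at this position a second methoxy does not move the number beyond the scatter. Among these compounds, the other placement of a second methoxy gives a 1.6-fold higher number from compound 2 to compound 3 (0.21 log units; within the scatter) and also stays within the scatter, so the place of the second methoxy does not separate the two compounds that carry two methoxy groups, and the only step here that clears the scatter remains the first methoxy, a 2.2-fold higher number from compound 1 to compound 2 (0.34 log units; beyond the scatter) in this short series. No measurement on hand accounts for these numbers.

The compounds shown leave open whether the flat result belongs to methoxy or to this position in general, since a hydroxyl, an amine or a carboxylic acid in the same place could give a different step in this assay. They also leave open whether a third methoxy on the same ring would stay within the scatter of compound 4 or would clear it.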